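This account rests on a few compounds, and the source may have more. Where it says the series, first, only, none or still open, it means among the compounds named here.

Compound 1 `CC[C@@H](C)Nc1nc(Cl)nc(N[C@@H](C)c2ccccc2)n1` was measured in an ADME assay on the whole organism for inhibition, with Oryza sativa as the target, with a stated time of 4 days (a higher number here means a weaker inhibitor, a lower number a stronger inhibitor), where compound 1 gives 9770 nM. Its companion, compound 2 `CC(C)Nc1nc(Cl)nc(N[C@H](C)c2ccccc2)n1`, gives 5370 nM in this assay. Of the two numbers shown, that of compound 1 is the larger, yet the gap to compound 2 falls within the usual scatter, so neither can be called the stronger inhibitor. Compound 3 `CCCN(CCC)c1nc(Cl)nc(N[C@@H](C)c2ccccc2)n1` differs from compound 1 in one place: dipropylamino in place of (sec-butyl)amino on an aromatic carbon. Going by the values given here, no measured pair shows such a change, so only a guess is possible; the expectation is a step no larger than the scatter, estimated as a 1.2-fold higher number from compound 1 to compound 3 (0.09 log units; within the scatter). Compound 3 is therefore expected to give about 12000 nM, within 4000 nM to 36000 nM.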

Compound 3, half-maximal inhibitory concentration: 331 nM
Beside the measured number, compound 3's estimate is 36-fold (1.56 log units) above it; the measured number lies below the stated range.
By their numbers in this assay, from the lowest: compound 3; then compounds 2 and 1 (each within the scatter of the next).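

This position on the shared core, on an aromatic carbon between two ring nitrogen atoms, proves highly sensitive in this assay: dipropylamino in place of (sec-butyl)amino gives a 30-fold lower number from compound 1 to compound 3 (1.47 log units; beyond the scatter), so compound 3 is the stronger inhibitor. The change removes the amine's hydrogen-bond donor, adds carbon and removes a defined stereocentre, all in one step. Nothing measured here explains the size of this step.

As far as these compounds go, it remains open which of these differences matters. It is also unclear whether diethylamino, dibutylamino or a ring such as piperidine at this position would give a similarly low number.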